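This account rests on a few compounds, and the source may have more. Where it says the series, first, only, none or still open, it means among the compounds named here.

Measured in a functional assay for inhibition, with Homo sapiens as the target; a higher number here means a weaker inhibitor, a lower number a stronger inhibitor:
compound 1 `Cc1cccc(Nc2nccc(-c3cccs3)n2)c1`, 300 nM;
compound 2 `NS(=O)(=O)c1cccc(Nc2nccc(-c3ccncc3)n2)c1`, 500 nM;
compound 3 `Cc1cccc(Nc2nccc(-c3ccncc3)n2)c1`, 8800 nM.

Compound 3 gives the highest number of the three, with a 29-fold higher number from compound 1 to compound 3 (1.47 log units; beyond the scatter) and an 18-fold higher number from compound 2 to compound 3 (1.25 log units; beyond the scatter) both placing it beyond the scatter from the others. Compound 4 `Cc1cccc(Nc2nccc(-c3ccco3)n2)c1` differs from compound 3 by furan-2-yl in place of pyridin-4-yl on an aromatic carbon. The step that bears on this change is a 29-fold higher number from compound 1 to compound 3 (1.47 log units; beyond the scatter), where a five-membered aromatic ring with one hetero atom, thiophen-2-yl, carried the far lower number; furan-2-yl is again a five-membered aromatic ring with one hetero atom, so a large fall in this assay is expected, although the thiophen-2-yl result cannot simply be carried over. Compound 4 is therefore estimated at 500 nM (range 150 nM to 1800 nM), an expected step of an 18-fold lower number from compound 3 to compound 4 (1.25 log units; beyond the scatter).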

Compound 4, half-maximal inhibitory concentration: 2100 nM
The estimate for compound 4 lay 4.2-fold (0.62 log units) below the measured number; measured number above the stated range.
By their numbers in this assay, from the lowest: compounds 1 and 2 (each within the scatter of the next); then compound 4; then compound 3.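

At this position on the shared core, furan-2-yl in place of pyridin-4-yl lowers the number in this assay only modestly (a 4.2-fold lower number from compound 3 to compound 4 (0.62 log units; beyond the scatter)). The two five-membered aromatic rings with one hetero atom are not interchangeable here, as furan-2-yl in place of thiophen-2-yl gives a 7.0-fold higher number from compound 1 to compound 4 (0.85 log units; beyond the scatter), so ring size and hetero atom count alone do not set the number. (Nothing at hand accounts for this gap)

Still open, from the compounds shown here alone, is whether sulfamoyl in place of methyl has a comparable effect alongside either five-membered ring. Also open, going by these compounds, is how an amine or a carboxylic acid on the five-membered ring would behave.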